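Swapping the Chlorophenyl End for a Naphthalene

The source may report more compounds than this note shows. Statements on the series, on what has been measured and on what is new or still open speak of the compounds shown alone.

Measured compounds:
compound 1 `O=S(=O)(NCCCNCc1ccccc1Cl)c1cc(C(F)(F)F)cc(C(F)(F)F)c1` — 13000 nM
compound 2 `CC(C)(C)c1ccc(CNCCCNS(=O)(=O)c2cc(C(F)(F)F)cc(C(F)(F)F)c2)cc1` — 2700 nM
compound 3 `O=S(=O)(NCCCNCc1ccccc1)c1cc(C(F)(F)F)cc(C(F)(F)F)c1` — 13000 nM

Within the data shown here, in a functional assay on ASPC1 cells (Homo sapiens) for inhibition, read by MTT assay, with a stated time of 72 h (on this read-out higher numbers stand for weaker inhibition of growth and lower numbers for stronger inhibition of growth), compound 1 gives 13000 nM, level with compound 3 and together with it the highest of the three numbers; compound 2 gives the only clearly lower value, a 4.8-fold lower number from compound 1 to compound 2 (0.68 log units; beyond the scatter). Compound 4 `O=S(=O)(NCCCNCc1cccc2ccccc12)c1cc(C(F)(F)F)cc(C(F)(F)F)c1` carries naphthalen-1-yl in place of 2-chlorophenyl on a saturated chain carbon bound to an amine nitrogen. Among the measured compounds shown here, two steps bear on this. no change at the digits printed from compound 1 to compound 3 (within the scatter), so the chloro that leaves is not what holds the number up. a 4.8-fold lower number from compound 1 to compound 2 (0.68 log units; beyond the scatter), showing that a ring end with more carbon can lower the number. The naphthalen-1-yl also adds carbon at that end, though differently from tert-butyl, so a modest lowering is expected, a 2.6-fold lower number from compound 1 to compound 4 (0.41 log units; beyond the scatter). Compound 4 is estimated at 5000 nM, within 1800 nM to 14000 nM.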

Compound 4, concentration for 50% growth inhibition: 21000 nM
Compound 4: the middle estimate sits 4.2-fold (0.62 log units) below what was measured; measured number above the stated range.
By their numbers in this assay, from the lowest: compound 2; then compounds 1, 3 and 4 (each within the scatter of the next).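

More carbon at this ring end does not by itself lower the number in this assay here: naphthalen-1-yl stays within the scatter of 2-chlorophenyl (a 1.6-fold higher number from compound 1 to compound 4 (0.21 log units; within the scatter)) and of phenyl (a 1.6-fold higher number from compound 3 to compound 4 (0.21 log units; within the scatter)). Only 4-(tert-butyl)phenyl stands clearly apart (a 7.8-fold higher number from compound 2 to compound 4 (0.89 log units; beyond the scatter)). No measurement shown accounts for this difference. Still open, as far as these compounds go, is how a smaller alkyl group such as methyl or isopropyl, or a methoxy group, would read on the phenyl ring, and whether a longer chain would alter the picture.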